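A larger aryl on the carbonyl carbon of the shared core

A few compounds are considered here, and "the series" means these few. Any claim that something is new, unique, unknown or untested is made for them only; others in the source may bear on it.

This account follows a series built on the core of compound 1 `COc1cc(-c2nnc3n2NC(c2ccco2)C(C(=O)c2ccco2)S3)cc(OC)c1OC`, a compound that is only weakly active. For the measured compounds named here, in a functional assay on PC-3 cells (Homo sapiens) for cytotoxicity, read by MTT assay, with a stated time of 48 h (a higher number here means a weaker inhibitor, a lower number a stronger inhibitor), compound 1 gives 58300 nM, the only number recorded for this series. Compound 2 `COc1ccc(C(=O)C2Sc3nnc(-c4cc(OC)c(OC)c(OC)c4)n3NC2c2ccco2)cc1` carries 4-methoxyphenyl in place of furan-2-yl on the carbonyl carbon. In this assay compound 2 reaches only the limit > 100000 nM, which is a limit of the assay and not a number. The step of an at least 1.7-fold higher number from compound 1 to compound 2 (0.23 log units; that floor lies within the scatter) is therefore known only as a floor, and that floor lies within the scatter; the relevant point is the limit of > 100000 nM in this assay, at which 1 of the 2 values shown sits.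

Compound 3 `COc1cc(-c2nnc3n2NC(c2ccco2)C(C(=O)c2ccc(-c4ccccc4)cc2)S3)cc(OC)c1OC` differs from compound 1 by the change (4-phenylphenyl in place of furan-2-yl on a carbonyl carbon). Going by the values given here, the only measured step that bears on it is the one from compound 1 to compound 2, where an aryl group replaced furan-2-yl at the same carbonyl carbon and the result fell to the limit. The step for compound 3 is expected to be of that kind, a 1.7-fold higher number from compound 1 to compound 3 (0.23 log units; within the scatter), toward a higher number, and quite possibly another limit. Compound 3 is thus estimated at 100000 nM in this assay, within a range from 40000 nM to 250000 nM.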

Compound 3, half-maximal inhibitory concentration: 45900 nM
Estimate against measurement, compound 3: 2.2-fold (0.34 log units) above; the range from low to high includes it.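

In this assay the exchange of furan-2-yl for 4-phenylphenyl on the carbonyl carbon gives a 1.3-fold lower number from compound 1 to compound 3 (0.10 log units; within the scatter) and so shows that an aryl group at this carbon does not by itself take a compound of this series to the limit, since compound 3 reads level with compound 1. For the compounds shown here, the change of methoxy to phenyl on an aromatic carbon gives an at least 2.1-fold lower number from compound 2 to compound 3 (0.33 log units; beyond the scatter) and is the first step beyond the scatter, which shows that the reading at this carbonyl carbon depends on what the aryl group carries and not only on its being an aryl group. Compound 2 stands at a limit of the assay and not at a number, so this step is known only as a floor and its true size stays open: the limit of > 100000 nM in this assay, at which 1 of the 3 values shown sits.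

As far as these compounds go, it remains open whether an amine or a carboxylic acid on that aryl group, or a longer chain on the carbonyl carbon, would move the reading beyond the scatter from compound 1. The compounds shown also do not tell whether any change at this carbon can give a clearly lower number than compound 1 at 58300 nM in this assay does.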